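A few compounds are considered here, and "the series" means these few. Any claim that something is new, unique, unknown or untested is made for them only; others in the source may bear on it.

Going by the values given here, compound 1 `N#Cc1cccc(C#Cc2cccc(C#N)n2)c1` gives 20 nM in an in vitro functional assay on HEK293-A cells for agonist activity at metabotropic glutamate receptor 5 (Rattus norvegicus), read by ELISA (a higher number here means a weaker inhibitor, a lower number a stronger inhibitor), the lowest of the two numbers measured so far. Compound 2 `N#Cc1cc(F)cc(C#Cc2cccc(F)n2)c1` gives 80 nM in this assay, a gap beyond the usual scatter. Among the compounds with values here, no measured pair differs in only one place, so no single step has been recorded. Compound 3 `CC(=O)c1cccc(C#Cc2cccc(C#N)c2)n1` remains to be measured in this assay; it differs from compound 1 by acetyl in place of cyano on an aromatic carbon. Within the data shown here, with no recorded step to lean on, a modest rise in the number is expected, of about a 2.5-fold higher number from compound 1 to compound 3 (0.40 log units; beyond the scatter). Compound 3 is thus expected to give 50 nM, in the range 15 nM to 200 nM.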

Compound 3, half-maximal inhibitory concentration: 300 nM
Compound 3: the middle estimate sits 6.0-fold (0.78 log units) below what was measured; measured number above the stated range.
By their numbers in this assay, from the lowest: compound 1; then compound 2; then compound 3.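

Acetyl in place of cyano, on the aromatic carbon next to the ring nitrogen, gives a 15-fold higher number from compound 1 to compound 3 (1.18 log units; beyond the scatter) in this assay, the first single-place step in the series. This position therefore responds strongly to the change, even though both groups count one hydrogen-bond acceptor and neither carries a net charge. No available evidence bears on the reason for this rise.

Going by these compounds, whether any replacement of cyano here raises the number, or only acetyl, remains open. An amine, a carboxylic acid or a methyl at this position would help to separate these readings.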